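The source may report more compounds than this note shows. Statements on the series, on what has been measured and on what is new or still open speak of the compounds shown alone.

Compound 1 `CCc1ccc(NS(=O)(=O)c2ccc(N3CCNC3=O)cc2)cc1`: 660 nM
Compound 2 `COc1ccccc1NS(=O)(=O)c1ccc(N2CCNC2=O)cc1`: 550 nM
Compound 3 `Cc1cccc(NS(=O)(=O)c2ccc(N3CCNC3=O)cc2)c1`: 110 nM

In a functional assay on HT-29 cells (Homo sapiens) for antiproliferative activity, read by sulforhodamine B assay, with a stated time of 48 h (on this read-out lower numbers stand for stronger inhibition and higher numbers for weaker inhibition), compound 1 gives the highest of the three numbers. Compound 2 sits within the scatter of compound 1, a 1.2-fold lower number from compound 1 to compound 2 (0.08 log units; within the scatter), whereas compound 3 is set apart from compound 1 by a 6.0-fold lower number from compound 1 to compound 3 (0.78 log units; beyond the scatter) and from compound 2 by a 5.0-fold lower number from compound 2 to compound 3 (0.70 log units; beyond the scatter). Compound 4 `CCCCCCCc1ccc(NS(=O)(=O)c2ccc(N3CCNC3=O)cc2)cc1` differs from compound 1 in one place: pentyl in place of hydrogen on a saturated chain carbon, two bonds along the chain from an aromatic carbon. Going by the values given here, neither measured step varies chain length at this place; both exchange the whole aryl group on the sulfonamide nitrogen, so no step bears directly on the change. The expectation is therefore a step not beyond the scatter, with a wide range. Compound 4 is estimated at 900 nM (range 300 nM to 3000 nM), an expected 1.4-fold higher number from compound 1 to compound 4 (0.13 log units; within the scatter).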

Compound 4, half-maximal inhibitory concentration: > 1000 nM
Compound 4 ended at the assay's limit; the forecaster's own chance of this, stated with the estimate: 10%; middle value at least 1.1-fold (0.04 log units) away from the limit.
By their numbers in this assay, from the lowest: compound 3; then compounds 2 and 1 (each within the scatter of the next). At a limit, above all of these: compound 4.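

In this assay compound 4 reads > 1000 nM, which is a limit of the assay and not a number. Pentyl in place of hydrogen on this saturated chain carbon gives an at least 1.5-fold higher number from compound 1 to compound 4 (0.18 log units; that floor lies within the scatter), so extending ethyl to heptyl brings no stronger inhibition here. Only the floor of this step can be read, so whether the true step exceeds the scatter stays unresolved: the limit of > 1000 nM in this assay, at which 1 of the 4 values shown sits.

Going by these compounds, whether a propyl or butyl chain at this place reads like the ethyl of compound 1 stays open. Also open, on these data alone, is how a chain carrying an amine or a carboxylic acid would read.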